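A few compounds are considered here, and "the series" means these few. Any claim that something is new, unique, unknown or untested is made for them only; others in the source may bear on it.

Three compounds with a shared core were tested in a functional assay on ASPC1 cells (Homo sapiens) for inhibition, read by MTT assay, with a stated time of 72 h; on this read-out lower numbers stand for stronger inhibition of growth and higher numbers for weaker inhibition of growth. Compound 2 `O=S(=O)(NCCCNCc1ccc(Cl)c(Cl)c1)c1cc(C(F)(F)F)cc(C(F)(F)F)c1` gives 2800 nM, the lowest of the three numbers shown, although compound 1 `O=S(=O)(NCCCCNCc1ccc(Br)cc1)c1cc(C(F)(F)F)cc(C(F)(F)F)c1` gives 2900 nM, a step of a 1.0-fold lower number from compound 1 to compound 2 (0.02 log units; within the scatter), and compound 3 `CN(CCCNS(=O)(=O)c1cc(C(F)(F)F)cc(C(F)(F)F)c1)Cc1ccccc1` gives 51000 nM. Compound 4 `O=S(=O)(NCCCNCc1ccccc1)c1cc(C(F)(F)F)cc(C(F)(F)F)c1` differs from compound 2 in one place: phenyl in place of 3,4-dichlorophenyl on a saturated chain carbon bound to an amine nitrogen. Going by the values given here, no measured step isolates this change. The steps of an 18-fold higher number from compound 1 to compound 3 (1.25 log units; beyond the scatter) and an 18-fold higher number from compound 2 to compound 3 (1.26 log units; beyond the scatter) were large, but each also exchanged the amine for a benzyl(methyl)amino group, so they bear on it only loosely. A moderate weakening is therefore expected in this assay for compound 4. Compound 4 is expected to give 8000 nM, with a range from 2500 nM to 25000 nM, which would mean a step of a 2.9-fold higher number from compound 2 to compound 4 (0.46 log units; beyond the scatter).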

Compound 4, concentration for 50% growth inhibition: 13000 nM
Compound 4: the middle estimate sits 1.6-fold (0.21 log units) below what was measured; measured number inside the range.
By their numbers in this assay, from the lowest: compounds 2 and 1 (each within the scatter of the next); then compound 4; then compound 3.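

In this assay, going by these compounds alone, phenyl in place of 3,4-dichlorophenyl gives a 4.6-fold higher number from compound 2 to compound 4 (0.67 log units; beyond the scatter), the first step to isolate the loss of the two chlorines on this ring. Hydrogen in place of methyl on the amine nitrogen gives a 3.9-fold lower number from compound 3 to compound 4 (0.59 log units; beyond the scatter), so the methyl change is now also seen alone. Benzylamino in place of ((4-bromobenzyl)amino)methyl gives a 4.5-fold higher number from compound 1 to compound 4 (0.65 log units; beyond the scatter), a step of similar size that also changes the chain. Nothing measured here gives a reason for these steps. As far as these compounds go, whether a single chlorine, a methoxy group or a nitrile on the phenyl ring would match 3,4-dichlorophenyl remains open.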